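Aryl Group Exchange in a Small Antiproliferative Series

A few compounds are considered here, and "the series" means these few. Any claim that something is new, unique, unknown or untested is made for them only; others in the source may bear on it.

Compound 1 `CCC1=C(O)c2c(oc(-c3cccc(OC)c3)cc2=O)C(CC)(CC)C1=O` — 13.3 uM
Compound 2 `CCC1=C(O)c2c(oc(-c3cc(OC)cc(OC)c3)cc2=O)C(CC)(CC)C1=O` — 45.2 uM

Of the compounds shown here, two have been measured in a functional assay on KB cells (Homo sapiens) for antiproliferative activity, read by sulforhodamine B assay, with a stated time of 3 days; a higher number here means that more compound is needed for the effect, a lower number that less compound is needed. Compound 1 gives 13.3 uM and stands at the lower of the two numbers; compound 2 gives 45.2 uM. For the measured compounds named here, the single measured step, a 3.4-fold higher number from compound 1 to compound 2 (0.53 log units; beyond the scatter), shows that adding a methoxy on the aryl ring of compound 1 moves the number upward.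

Compound 3 `CCC1=C(O)c2c(oc(-c3cc(C)ccc3F)cc2=O)C(CC)(CC)C1=O` has not yet been measured. It differs from compound 1 in one place: 2-fluoro-5-methylphenyl in place of 3-methoxyphenyl on an aromatic carbon. Going by the values given here, no measured step covers this exchange; the only step available replaces hydrogen with methoxy and does not remove the methoxy or introduce fluorine or methyl. The new group matches the old one in size, so the change is expected to be small. Compound 3 is therefore estimated to land close to compound 1, at 15 uM, within a range of 5 uM to 45 uM. The step this estimate implies is a 1.1-fold higher number from compound 1 to compound 3 (0.05 log units; within the scatter), which is expected to stay within the scatter.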

Compound 3, concentration for half-maximal effect: 47.3 uM
Beside the measured number, compound 3's estimate is 3.2-fold (0.50 log units) below it; measured number outside the range, above it.
By their numbers in this assay, from the lowest: compound 1; then compounds 2 and 3 (each within the scatter of the next).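

Replacing 3-methoxyphenyl with 2-fluoro-5-methylphenyl in this assay gives a clear rise (a 3.6-fold higher number from compound 1 to compound 3 (0.55 log units; beyond the scatter)), although both groups count 8 heavy atoms and one six-membered aromatic ring of carbon only, so at this position a matching heavy-atom count does not keep the number at the level of compound 1. The earlier step, which adds a methoxy (a 3.4-fold higher number from compound 1 to compound 2 (0.53 log units; beyond the scatter)), showed only that adding to the aryl ring of compound 1 raises the number; this exchange removes the methoxy and still raises it, leaving compound 1 with the lowest number of the three compounds in this small set. Nothing available here accounts for the rise on exchange.

The exchange changes the methoxy, the fluorine and the methyl at once, so the compounds shown cannot say which of them carries the step, and a phenyl with only a methyl or only a fluorine would separate them. Going by these compounds, it also remains open whether any aryl group at this position gives a lower number than compound 1 does, for instance a plain phenyl, a 3-hydroxyphenyl or a 3-aminophenyl.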